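The source may report more compounds than this note shows. Statements on the series, on what has been measured and on what is new or still open speak of the compounds shown alone.

Compound 1 `c1ccc(-c2ccc(CCc3nc(CC4CCCC4)c[nH]3)cc2)nc1` gives 103 nM in a functional assay on HEK293 cells for agonist activity at Bombesin receptor subtype-3 (Mus musculus), read by luminescence and calcium flux, with a stated time of 10 min; a lower number here means that less compound is needed, a higher number that more compound is needed for the effect. Compound 2 `CCC(C)(C)Cc1c[nH]c(CCc2ccc(-c3csnn3)cc2)n1` gives 109 nM in this assay. Compound 3 `CCC(C)(C)Cc1c[nH]c(CCc2ccc(-c3cnsc3)cc2)n1` gives 119 nM in this assay.

Compound 3 stands within the scatter of both other compounds, so the three numbers cannot be told apart. Compound 4 `CCC(C)(C)Cc1c[nH]c(CCc2ccc(-n3cncn3)cc2)n1` is not yet measured. It differs from compound 3 as follows: 1H-1,2,4-triazol-1-yl in place of 1,2-thiazol-4-yl on an aromatic carbon. Among the measured compounds shown here, the one measured step that bears on this is the exchange of one five-membered heteroaryl for another on the same aromatic carbon, a 1.1-fold higher number from compound 2 to compound 3 (0.04 log units; within the scatter), which lay within the scatter. On that basis compound 4 is expected to show no step beyond the scatter in this assay, and the estimated step of a 1.0-fold higher number from compound 3 to compound 4 (0.00 log units; within the scatter) is accordingly small. Compound 4 is therefore estimated at 120 nM, with a range from 60 nM to 240 nM.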

Compound 4, half-maximal effective concentration: 121 nM
The estimate for compound 4 lay 1.0-fold (0.00 log units) below the measured number, and the stated range covers the measured number.
By their numbers in this assay, from the lowest: compounds 1, 2, 3 and 4 (each within the scatter of the next).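

Placed on the six-membered aromatic ring of carbon only, para to a large group, 1H-1,2,4-triazol-1-yl carries no sulfur, yet exchanging it for 1,2-thiazol-4-yl gives a 1.0-fold higher number from compound 3 to compound 4 (0.01 log units; within the scatter) in this assay, and exchanging it for 1,2,3-thiadiazol-4-yl gives a 1.1-fold higher number from compound 2 to compound 4 (0.05 log units; within the scatter). Both steps lie within the scatter, so the presence of sulfur in this five-membered aromatic ring makes no readable difference among these compounds. No supporting measurement bears on why this exchange is tolerated. Going by these compounds, what an amine or a carboxylic acid would give at this place remains open, since all three groups compared here are five-membered aromatic rings.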